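Ether amide series: lipophilicity working notes

The compounds below may be only part of what the source reports. "The series", "measured", "known", "first", "only" and "open" are said of these compounds alone.

Compound 2 `COc1ccc(NC(=O)COc2cc(C)nc3ccc(OC)cc23)cc1` stands second highest of the three numbers in a physicochemical assay for lipophilicity, read by HPLC, in phosphate buffer, measured as chromatographic lipophilicity, at pH 7.4 (on this read-out lower numbers stand for lower lipophilicity and higher numbers for higher lipophilicity), where compound 2 gives 4.22. Compound 1 `COc1ccc2c(OCC(=O)Nc3cc(C)cc(C)c3)cc(C)nc2c1` gives 5.59 in this assay, and compound 3 `COc1ccc2nc(C)cc(OCC(=O)Nc3ccc(S(=O)(=O)Nc4cc(C)on4)cc3)c2c1` gives 2.2. Among the measured compounds shown here, the one measured step, a number 2.02 log units lower from compound 2 to compound 3 (beyond the scatter), is the only comparison so far.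

Compound 4 `COc1ccc2nc(C)cc(OCC(=O)NNC(=O)c3ccncc3)c2c1` differs from compound 2 by ((pyridin-4-yl)carbonyl)amino in place of 4-methoxyphenyl on an amide-type nitrogen. The step of a number 2.02 log units lower from compound 2 to compound 3 (beyond the scatter) bears on this change, as it also exchanged a methoxy-bearing substituent for a larger heteroaromatic group and was large. By analogy a large step downward is expected, a number 2.22 log units lower from compound 2 to compound 4 (beyond the scatter), well beyond the scatter. Compound 4 is therefore estimated at 2 in this assay, with a range from 1.3 to 2.8.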

Compound 4, distribution coefficient: 1.48
For compound 4 the middle estimate is 0.52 log units above the measured one, and the stated range covers the measured number.
By their numbers in this assay, from the lowest: compound 4; then compound 3; then compound 2; then compound 1.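

In this assay, ((pyridin-4-yl)carbonyl)amino in place of 4-methoxyphenyl on an amide-type nitrogen gives a number 2.74 log units lower from compound 2 to compound 4 (beyond the scatter). This is the first step shown in which the whole aromatic group on that nitrogen is exchanged, whereas the earlier step changed only a substituent on an aromatic carbon. Nothing available explains the size of this step.

As far as these compounds go, it remains open whether the step follows the ring hetero atom or the added carbonyl and amino link. A benzoylamino group or a pyridin-4-yl group on the same nitrogen would separate the two.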